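Anilino series: phenyl to 4-methoxyphenyl

This account rests on a few compounds, and the source may have more. Where it says the series, first, only, none or still open, it means among the compounds named here.

Measured in a functional assay on A549 cells (Homo sapiens) for cytotoxicity, read by sulforhodamine B assay; on this read-out lower numbers stand for stronger inhibition and higher numbers for weaker inhibition:
- compound 1 `C=C1[C@@H](OC(C)=O)C[C@@H]2[C@](C)(COC=O)[C@H](OC(C)=O)CC[C@@]2(C)[C@@H]1C[C@@H](Nc1cccc(F)c1)C1=CCOC1=O`: 23200 nM
- compound 2 `C=C1[C@@H](OC(C)=O)C[C@@H]2[C@](C)(COC=O)[C@H](OC(C)=O)CC[C@@]2(C)[C@@H]1C[C@@H](Nc1ccccc1C(=O)O)C1=CCOC1=O`: 45900 nM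
- compound 3 `C=C1[C@@H](OC(C)=O)C[C@@H]2[C@](C)(COC=O)[C@H](OC(C)=O)CC[C@@]2(C)[C@@H]1C[C@@H](Nc1ccccc1)C1=CCOC1=O`: 25800 nM

Compound 3 stands within the scatter of both other compounds, so the three values give no firm order. Compound 4 `C=C1[C@@H](OC(C)=O)C[C@@H]2[C@](C)(COC=O)[C@H](OC(C)=O)CC[C@@]2(C)[C@@H]1C[C@@H](Nc1ccc(OC)cc1)C1=CCOC1=O` differs from compound 3 by methoxy in place of hydrogen on an aromatic carbon, para to a large group. The nearest measured changes on this aromatic ring are a 1.1-fold higher number from compound 1 to compound 3 (0.05 log units; within the scatter) and a 1.8-fold lower number from compound 2 to compound 3 (0.25 log units; within the scatter). Both stay within the scatter, though neither involves methoxy. No shift beyond the scatter is therefore expected in this assay. The expected step is a 1.1-fold lower number from compound 3 to compound 4 (0.03 log units; within the scatter). Compound 4 is estimated at 24000 nM, with an expected range of 12000 nM to 48000 nM.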

Compound 4, half-maximal inhibitory concentration: 28900 nM
Beside the measured number, compound 4's estimate is 1.2-fold (0.08 log units) below it, within the range that was stated.
By their numbers in this assay, from the lowest: compounds 1, 3, 4 and 2 (each within the scatter of the next).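

Methoxy, on an aromatic carbon para to a large group, adds a substituted place on this ring to those shown earlier, and in this assay the step is a 1.1-fold higher number from compound 3 to compound 4 (0.05 log units; within the scatter). The two other steps, a 1.6-fold lower number from compound 2 to compound 4 (0.20 log units; within the scatter) and a 1.2-fold higher number from compound 1 to compound 4 (0.10 log units; within the scatter), also stay within the scatter, so the substituents shown on this ring do not separate in this assay. No evidence on hand bears on this result.
Open, going by these compounds, is whether an amine or a longer alkoxy chain at this same place would give a step beyond the scatter.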